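This account rests on a few compounds, and the source may have more. Where it says the series, first, only, none or still open, it means among the compounds named here.

Measured so far in a functional assay on ACHN cells (Homo sapiens) for inhibition, read by sulforhodamine B assay, with a stated time of 48 h, tested at 10 uM; on this read-out lower numbers stand for less inhibition and higher numbers for more inhibition at the one concentration tested (going by the name of the read-out):
compound 1, `Brc1cn2ccnc2c(-c2ccc3ncn(C4CCCCC4)c3c2)n1`, gives 11.5%;
compound 2, `O=Cc1ccc(-c2cn3ccnc3c(-c3ccc4ncn(C5CCCCC5)c4c3)n2)cc1`, gives 11.6%.

Of these two numbers, compound 2 holds the upper one, but only by a number 0.1 percentage points higher from compound 1 to compound 2 (within the scatter), and that step lies within the scatter, so on this read-out the two compounds cannot be told apart. Both sit at a low level of inhibition at the single concentration tested.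

Compound 3, `Fc1ccccc1-c1cn2ccnc2c(-c2ccc3ncn(C4CCCCC4)c3c2)n1`, has not yet been measured. It differs from compound 2 in one place: 2-fluorophenyl in place of 4-formylphenyl on an aromatic carbon. The group that is exchanged sits at the same aromatic carbon that carried the bromo in compound 1 and the 4-formylphenyl in compound 2. Among the measured compounds shown here, the only measured step therefore bears directly on this position, and it was small: a number 0.1 percentage points higher from compound 1 to compound 2 (within the scatter), within the scatter. A bromo and a 4-formylphenyl are quite different groups, yet the read-out did not move, which suggests that this position is not sensitive on this assay. For the swap to 2-fluorophenyl, no step beyond the scatter is expected, and the estimated change is a number 0.4 percentage points higher from compound 2 to compound 3 (within the scatter). Compound 3 is thus expected to give about 12%, with a likely range from 0% to 28%.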

Compound 3, a percentage reported as inhibition, at one concentration (the size of the read-out at that concentration, not a potency): 13.2%
Beside the measured number, compound 3's estimate is 1.2 percentage points below it; measured number inside the range.
By their numbers in this assay, from the lowest: compounds 1, 2 and 3 (each within the scatter of the next).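

In this assay, a 2-fluorophenyl at this aromatic carbon cannot be told apart from either earlier group: the swap from 4-formylphenyl gives a number 1.6 percentage points higher from compound 2 to compound 3 (within the scatter), and the swap from bromo gives a number 1.7 percentage points higher from compound 1 to compound 3 (within the scatter). The earlier pair compared a bromo with a phenyl ring, whereas this result adds a comparison between two phenyl rings that carry different substituents in different places, and it shows that losing the formyl group's double bond and hydrogen-bond acceptor while gaining a fluorine also produces no step beyond the scatter. Nothing measured alongside these numbers bears on what lies behind this flat result.

All three compounds keep the same core and the same cyclohexyl group, and the group at this carbon has so far been a bromo or an uncharged phenyl ring, so these data cannot show whether changing the cyclohexyl would raise the inhibition. On these data alone, it also remains open whether an amine, a carboxylic acid or a longer alkyl chain at this carbon would move the number beyond the scatter.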